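The compounds below may be only part of what the source reports. "The series", "measured", "known", "first", "only" and "open" are said of these compounds alone.

Three compounds of the series share one core and differ only at the saturated chain carbon bound to an oxygen on an unsaturated carbon. Compound 1 `CCC1(Cc2ccccc2)OS(=O)(=O)C=C1OCc1ccc(OC)cc1` carries a 4-methoxyphenyl group there; in an ADME assay on HEL cells (Homo sapiens) for cytotoxicity, with a stated time of 3 days (on this read-out higher numbers stand for lower toxicity in this test and lower numbers for higher toxicity in this test), compound 1 gives only a limit of >= 200000 nM. Compound 2 `CCC1(Cc2ccccc2)OS(=O)(=O)C=C1OCc1ccc([N+](=O)[O-])cc1` carries a 4-nitrophenyl group; in this assay compound 2 gives a limit of >= 80000 nM. Compound 3 `CCC1(Cc2ccccc2)OS(=O)(=O)C=C1OCc1cccc(Cl)c1` carries a 3-chlorophenyl group; in this assay compound 3 gives a limit of >= 20000 nM. The steps a step that the two limits leave unreadable from compound 1 to compound 3 and a step that the two limits leave unreadable from compound 2 to compound 3 alter this same position and leave no readable size, and a step that the two limits leave unreadable from compound 1 to compound 2 likewise. Compound 4 `CCC1(Cc2ccccc2)OS(=O)(=O)C=C1OCCCc1ccccc1` differs from compound 3 by phenethyl in place of 3-chlorophenyl on a saturated chain carbon bound to an oxygen on an unsaturated carbon. With every step at this position unreadable, no step beyond the scatter can be expected in this assay, and a limit is likely again. Compound 4 is estimated at 50000 nM in this assay, within 20000 nM to 200000 nM, an expected step that the limit leaves unreadable from compound 3 to compound 4.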

Compound 4, minimum cytotoxic concentration: >= 20000 nM
Compound 4 was reported as a limit; the forecaster's own chance of this, stated with the estimate: 80%; the middle value lies beyond the limit too.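

In this assay compound 4 gives only a limit of >= 20000 nM. Its steps from compound 1, compound 2 and compound 3 cannot be read. The compounds shown leave open whether the group at this position changes cytotoxicity at all.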